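Extending the hydroxycarbamoyl chain of compound 3

The source may report more compounds than this note shows. Statements on the series, on what has been measured and on what is new or still open speak of the compounds shown alone.

- Compound 1 `COc1ccc(Nc2nc(Nc3cnn(CCCCCCC(=O)NO)c3)ncc2Cl)cc1`: 130 nM
- Compound 2 `O=C(CCCCCCn1cc(Nc2ncc(Cl)c(Nc3ccccc3)n2)cn1)NO`: 90 nM
- Compound 3 `O=C(CCCCCn1cc(Nc2ncc(Cl)c(Nc3ccccc3Cl)n2)cn1)NO`: 310 nM

In a functional assay on Jurkat cells (Homo sapiens) for antiproliferative activity, read by MTT assay, with a stated time of 48 h (on this read-out lower numbers stand for stronger inhibition and higher numbers for weaker inhibition), compound 3 gives the highest number of the three, beyond the scatter of both others. Compound 4 `O=C(CCCCCCn1cc(Nc2ncc(Cl)c(Nc3ccccc3Cl)n2)cn1)NO` is made from it by one change: (hydroxycarbamoyl)methyl in place of hydroxycarbamoyl on a saturated chain carbon, five bonds along the chain from an aromatic nitrogen. For the measured compounds named here, the only measured step, a 1.4-fold lower number from compound 1 to compound 2 (0.16 log units; within the scatter), puts hydrogen in place of methoxy on an aromatic carbon, lies within the scatter and leaves the chain untouched. So no measured step tests this change directly. Compound 1 at 130 nM and compound 2 at 90 nM carry the longer chain, but they also differ from compound 3 elsewhere. A modest lowering in this assay is therefore expected, an estimated 1.9-fold lower number from compound 3 to compound 4 (0.29 log units; within the scatter). For compound 4 the estimate is 160 nM, with an expected range of 60 nM to 380 nM.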

Compound 4, half-maximal inhibitory concentration: 250 nM
Estimate against measurement, compound 4: 1.6-fold (0.19 log units) below, within the range that was stated.
By their numbers in this assay, from the lowest: compounds 2, 1, 4 and 3 (each within the scatter of the next, the first and the last beyond it).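

At this position, the change to (hydroxycarbamoyl)methyl gives a 1.2-fold lower number from compound 3 to compound 4 (0.09 log units; within the scatter), so this one added chain carbon does not separate the two compounds. Chloro in place of hydrogen on an aromatic carbon gives the one step here beyond the scatter, a 2.8-fold higher number from compound 2 to compound 4 (0.44 log units; beyond the scatter), whereas 2-chlorophenyl in place of 4-methoxyphenyl on a nitrogen on an aromatic ring gives a 1.9-fold higher number from compound 1 to compound 4 (0.28 log units; within the scatter). No available evidence accounts for these steps. The compounds shown leave open how a longer chain, or a carboxylic acid in place of hydroxycarbamoyl, would fare here.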